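The compounds below may be only part of what the source reports. "The series", "measured", "known", "first", "only" and "open" are said of these compounds alone.

Measured so far:
- Compound 1, `Cc1nc2ccc(Cl)cc2c(-c2ccc(F)cc2)c1/C=C/[C@@H]1C[C@@H](O)CC(=O)O1`: 720 nM
- Compound 2, `CC(C)c1nc2ccc(Cl)cc2c(-c2ccc(F)cc2)c1/C=C/[C@@H]1C[C@@H](O)CC(=O)O1`: 25 nM

Both compounds were tested in an assay for inhibition of 3-hydroxy-3-methylglutaryl-coenzyme A reductase (Rattus norvegicus); on this read-out lower numbers stand for stronger inhibition and higher numbers for weaker inhibition. Compound 1 gives 720 nM in this assay, and compound 2 gives 25 nM. For the measured compounds named here, the only step between them is a 29-fold lower number from compound 1 to compound 2 (1.46 log units; beyond the scatter), so compound 2 stands as the lower of the two numbers, the stronger inhibitor of the pair.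

Compound 3, `CC(C)c1nc2ccccc2c(-c2ccc(F)cc2)c1/C=C/[C@@H]1C[C@@H](O)CC(=O)O1`, has not yet been tested in this assay. It differs from compound 2 by hydrogen in place of chloro on an aromatic carbon. Going by the values given here, the one measured step, from compound 1 to compound 2, concerns the group on the other ring of the shared core and says nothing about the chloro on the six-membered carbon ring of the fused system. Among the compounds with values here, there is therefore no measured step that bears on this change, and the expectation can rest only on the untouched remainder of compound 2, which keeps the isopropyl that produced a 29-fold lower number from compound 1 to compound 2 (1.46 log units; beyond the scatter).

With that, compound 3 is expected to give a number close to that of compound 2, a step of a 1.1-fold lower number from compound 2 to compound 3 (0.06 log units; within the scatter) that lies within the scatter. The estimate for compound 3 in this assay is 22 nM, with a range from 7 nM to 70 nM.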

Compound 3, half-maximal inhibitory concentration: 32 nM
Estimate against measurement, compound 3: 1.5-fold (0.16 log units) below; the range from low to high includes it.
By their numbers in this assay, from the lowest: compounds 2 and 3 (each within the scatter of the next); then compound 1.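

In this assay, hydrogen in place of chloro on this aromatic carbon gives a 1.3-fold higher number from compound 2 to compound 3 (0.11 log units; within the scatter) and so leaves compound 2 and compound 3 indistinguishable on this read-out. With the isopropyl in place, this position, meta to a fused ring and para to a fused ring, therefore accepts either chloro or hydrogen with no change that can be told from ordinary measurement scatter, while the swap on the other side of the shared core, a 29-fold lower number from compound 1 to compound 2 (1.46 log units; beyond the scatter), lies well beyond that scatter. Nothing measured alongside these numbers explains why the chloro can be exchanged for hydrogen here.

Going by these compounds, it remains open whether the exchange of chloro for hydrogen would be equally silent with methyl rather than isopropyl on the core, as in compound 1. On these data alone, it is also open whether larger or differently built groups on this same aromatic carbon, such as a methoxy group, an amine or a carboxylic acid, would fit in as readily as chloro and hydrogen do, or would move the number in either direction.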